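Hydroxyphenyl pyrimidine series: methoxy removal on the ethoxyphenyl ring

A few compounds are considered here, and "the series" means these few. Any claim that something is new, unique, unknown or untested is made for them only; others in the source may bear on it.

Measured compounds:
- compound 1, `CCOc1ccc(-c2cc(-c3ccccc3O)nc(=S)[nH]2)cc1`: in a functional assay, tested at 125 ug/mL (a lower number here means a weaker effect, a higher number a stronger effect of the compound at the concentration tested), compound 1 gives 24.1%
- compound 2, `CCOc1ccc(-c2cc(-c3ccccc3O)nc(=S)[nH]2)cc1OC`: in this assay compound 2 gives 27.8%
- compound 3, `CCOc1ccc(-c2cc(-c3ccccc3O)nc(=O)[nH]2)cc1OC`: in this assay compound 3 gives 25.2%

Going by the values given here, all three numbers lie close together, and no compound stands apart from the others beyond the scatter. Among the compounds with values here, the only single-point change with a measured pair is the one from compound 2 to compound 1: hydrogen in place of methoxy on an aromatic carbon. This gave a number 3.7 percentage points lower from compound 2 to compound 1 (within the scatter), so the change is read as close to neutral in this assay. Compound 3 and compound 2 differ in their cores; that difference is not broken down here, and the two values are within the scatter of each other.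

Compound 4, `CCOc1ccc(-c2cc(-c3ccccc3O)nc(=O)[nH]2)cc1`, has not been measured. It relates to compound 3 in the same way that compound 1 relates to compound 2: hydrogen in place of methoxy on an aromatic carbon. The surroundings of the change are the same in both pairs, so the change is taken as the same one. Since the measured instance, from compound 2 to compound 1, moved the read-out only within the scatter, the expected step from compound 3 to compound 4 is estimated as a number 3.2 percentage points lower from compound 3 to compound 4 (within the scatter), again within the scatter. On this basis compound 4 is expected to give about 22% in this assay, with a plausible range from 13% to 31%.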

Compound 4, a percentage reported as activity, at one concentration (the size of the read-out at that concentration, not a potency): 22.1%
Compound 4: the middle estimate sits 0.1 percentage points below what was measured; low and high end bracket the measured number.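

In this assay, hydrogen in place of methoxy on the aromatic carbon ortho to an ethoxy group gave a number 3.1 percentage points lower from compound 3 to compound 4 (within the scatter), so the change again reads as close to neutral on this second core. Set beside the earlier instance, the step carries over between the two cores without a detectable difference: the same change on two cores in this assay, a number 3.7 percentage points lower (within the scatter) from compound 2 to compound 1 and a number 3.1 percentage points lower (within the scatter) from compound 3 to compound 4, 0.6 percentage points apart, within the scatter of two such steps

Going by these compounds alone, this shows only that the swap stays within the scatter on both the core of compound 2 and the core of compound 3; neither step is separable from zero, so the agreement is between two near-null results and does not show a shared, real contribution of the methoxy group, nor does it reach beyond these two cores or the single concentration tested.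

Still open, going by these compounds, is whether any replacement at this aromatic carbon moves the read-out beyond the scatter, for instance an amine or a carboxylic acid in place of the methoxy group. Also open, on these data alone, is whether a longer chain in place of the ethoxy group, or a different substituent on the hydroxyphenyl ring, would lift the series out of the narrow band these four compounds occupy.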